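The source may report more compounds than this note shows. Statements on the series, on what has been measured and on what is new or still open speak of the compounds shown alone.

In an in vitro assay on Sf21 cells for inhibition of high affinity 3',5'-cyclic-AMP phosphodiesterase 7A (Homo sapiens) (on this read-out higher numbers stand for weaker inhibition and lower numbers for stronger inhibition), compound 2 `CNc1nc(NC2(C#N)CCCCC2)nc(N(C)C)n1` sits at the limit of > 5000 nM in this assay, at which 1 of the 3 values shown sits. Compound 2 gives > 5000 nM there, which is a limit of the assay and not a number. Compound 1 `CNc1nc(NC2(C#N)CCCCC2)nc(-n2ccnc2)n1` gives 1050 nM in this assay. Compound 3 `CNc1nc(NC2(C#N)CCCCC2)nc(-n2cnc3ccccc32)n1` stands at the limit of > 1000 nM in this assay, at which 1 of the 3 values shown sits, and compound 3 gives > 1000 nM, again a limit rather than a number. Among the measured compounds shown here, the single measured step that touches compound 2 is an at least 4.7-fold higher number from compound 1 to compound 2 (0.67 log units; beyond the scatter), so the loss of the 1H-imidazol-1-yl for dimethylamino cost inhibition in this assay. Compound 4 `CNc1nc(NC2(C#N)CCCCC2)nc(-n2cnc(C)n2)n1` arises from compound 2 by 3-methyl-1H-1,2,4-triazol-1-yl in place of dimethylamino on an aromatic carbon. This change restores a five-membered aromatic ring at the same carbon, and on the strength of the measured step of an at least 4.7-fold higher number from compound 1 to compound 2 (0.67 log units; beyond the scatter) the present change is expected to run in the opposite direction. The expected step is an at least 3.3-fold lower number from compound 2 to compound 4 (0.52 log units; beyond the scatter), bringing compound 4 back toward where compound 1 stands. Compound 4 is therefore estimated at 1500 nM in this assay, with a range from 500 nM to 5000 nM.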

Compound 4, half-maximal inhibitory concentration: > 5000 nM
Compound 4: no number, only a limit (the forecaster's own chance of this, stated with the estimate: 30%); middle value at least 3.3-fold (0.52 log units) away from the limit.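

In this assay, compound 4 gives a limit and not a number, the same limit that compound 2 reaches: the limit of > 5000 nM in this assay, at which 2 of the 4 values shown sit. The step between those two compounds cannot be read, but there is an at least 4.7-fold higher number from compound 1 to compound 4 (0.67 log units; beyond the scatter), which shows that a five-membered aromatic ring on this carbon, opposite the ring nitrogen, does not by itself keep the inhibition of compound 1. Among the groups shown at this place, only 1H-imidazol-1-yl yields a number, with compound 1 at 1050 nM.

The 3-methyl-1H-1,2,4-triazol-1-yl group differs from 1H-imidazol-1-yl both in its ring nitrogens and in its methyl, and the compounds shown do not separate the two. An unsubstituted 1H-1,2,4-triazol-1-yl or a 4-methyl-1H-imidazol-1-yl at this carbon would tell them apart.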